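Working notes before measurement of compound 4

This account rests on a few compounds, and the source may have more. Where it says the series, first, only, none or still open, it means among the compounds named here.

Measured so far in an assay on membranes from HeLa cells for displacement of a labelled ligand from adenosine receptor A3 (Homo sapiens), read by scintillation counting, with a stated time of 180 min, tested at 1 uM; on this read-out higher numbers stand for more inhibition at the one concentration tested (going by the name of the read-out) and lower numbers for less inhibition:
- compound 1 `CCCC(=O)C1=C(C)NC(=O)NC1c1ccsc1` gives 1%
- compound 2 `CCC(CC)OC(=O)C1=C(C)NC(=O)NC1c1ccsc1` gives 6%
- compound 3 `CC1=C(C(=O)OC2CCCC2)C(c2ccsc2)NC(=O)N1` gives 5%

Compound 3 has the second highest of the three numbers. Its nearest neighbour is compound 2, with a number 1 percentage points lower from compound 2 to compound 3 (within the scatter); the furthest is compound 1, with a number 4 percentage points higher from compound 1 to compound 3 (within the scatter). Both steps lie within the scatter, so no order among the three compounds can be read, and all three numbers sit low on this read-out.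

Compound 4 `CC1=C(C(=O)OCC2CCC2)C(c2ccsc2)NC(=O)N1` differs from compound 3 in one place: cyclobutylmethyl in place of cyclopentyl on an oxygen next to a carbonyl group.

The step that bears most directly on this change is the earlier one on the same oxygen, a number 1 percentage points lower from compound 2 to compound 3 (within the scatter), which stayed within the scatter. The two changes on the carbonyl carbon, a number 5 percentage points higher from compound 1 to compound 2 (within the scatter) and a number 4 percentage points higher from compound 1 to compound 3 (within the scatter), likewise stayed within the scatter. For the measured compounds named here, nothing measured so far has moved the read-out beyond its noise, and the present change is of the same kind as the step from compound 2 to compound 3. The expected step is therefore no change at the digits printed from compound 3 to compound 4 (within the scatter), none beyond the scatter.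

For compound 4 the estimate is 5%, expected within 0% to 15%.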

Compound 4, a percentage reported as inhibition, at one concentration (the size of the read-out at that concentration, not a potency): 2%
Compound 4: the middle estimate sits 3 percentage points above what was measured; measured number inside the range.
By their numbers in this assay, from the lowest: compounds 1, 4, 3 and 2 (each within the scatter of the next).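

In this assay, for the compounds shown here, cyclobutylmethyl in place of cyclopentyl on an oxygen next to a carbonyl group is the first change here that keeps the same atoms and joins them differently, turning a five-membered ring into a four-membered ring, and it gives a number 3 percentage points lower from compound 3 to compound 4 (within the scatter). The other steps to compound 4, a number 4 percentage points lower from compound 2 to compound 4 (within the scatter) and a number 1 percentage points higher from compound 1 to compound 4 (within the scatter), also stay inside the noise, so a third group on this oxygen still yields no readable order among the four compounds. No supporting measurement bears on this result.

On these data alone, whether an amine, a carboxylic acid or a longer chain on this oxygen would move the read-out beyond the scatter stays open. Also open, as far as these compounds go, is whether a change elsewhere on the shared core would do so.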